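A sulfonyl exchanged for a benzylsulfanyl group

This account rests on a few compounds, and the source may have more. Where it says the series, first, only, none or still open, it means among the compounds named here.

- compound 1 `O=C(/C(=C\c1ccc([N+](=O)[O-])c(O)c1)SCc1ccc(Br)cc1)c1ccc([N+](=O)[O-])c(Cl)c1` at 1000 nM in the measurement below
- compound 2 `O=C(/C(=C\c1ccc([N+](=O)[O-])c(O)c1)S(=O)(=O)c1ccc(Br)cc1)c1c(F)c(F)c(F)c(F)c1F` at 1000 nM in the same measurement

In a functional assay on DU-145 cells (Homo sapiens) for inhibition, read by trypan blue exclusion, with a stated time of 96 h (on this read-out higher numbers stand for weaker inhibition of growth and lower numbers for stronger inhibition of growth), compound 2 stands level with compound 1 within the scatter. Compound 3 `O=C(/C(=C\c1ccc([N+](=O)[O-])c(O)c1)SCc1ccc(Br)cc1)c1c(F)c(F)c(F)c(F)c1F` departs from compound 2 through one change (4-bromobenzyl)sulfanyl in place of (4-bromophenyl)sulfonyl on a double-bonded chain carbon bound to a carbonyl carbon and a double-bonded chain carbon with (4-bromobenzyl)sulfanyl in place of (4-bromophenyl)sulfonyl on a double-bonded chain carbon bound to a carbonyl carbon and a double-bonded chain carbon. Compound 1 already carries the entering group, and compound 1 at 1000 nM matches compound 2 at 1000 nM so no shift beyond the scatter is expected in this assay for this change. The expected step of no change at the digits printed from compound 2 to compound 3 (within the scatter) is small, with neither direction favoured. Compound 3 is estimated at 1000 nM with a range from 350 nM to 3000 nM in this measurement.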

Compound 3, concentration for 50% growth inhibition: 10000 nM
Estimate against measurement, compound 3: 10-fold (1.00 log units) below; measured number above the stated range.
By their numbers in this assay, from the lowest: compounds 1 and 2 (each within the scatter of the next); then compound 3.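

In this assay, with 2,3,4,5,6-pentafluorophenyl on the carbonyl carbon, (4-bromobenzyl)sulfanyl in place of (4-bromophenyl)sulfonyl gives a 10-fold higher number from compound 2 to compound 3 (1.00 log units; beyond the scatter), so this exchange is not neutral. With (4-bromobenzyl)sulfanyl kept, 2,3,4,5,6-pentafluorophenyl in place of 3-chloro-4-nitrophenyl gives a 10-fold higher number from compound 1 to compound 3 (1.00 log units; beyond the scatter), so the group on the carbonyl carbon also counts. No measurement shown gives a reason for either step.

As far as these compounds go, it remains open how a (4-bromophenyl)sulfanyl group or an amine would stand on the double-bonded chain carbon, and whether the exchange would have the same size with 3-chloro-4-nitrophenyl on the carbonyl carbon.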